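Swapping Piperidine for Morpholine in Two Weakly Active Series

A few compounds are considered here, and "the series" means these few. Any claim that something is new, unique, unknown or untested is made for them only; others in the source may bear on it.

Compound 1 `O=c1cc(CSC(=S)N2CCCCC2)oc2cc(Cl)ccc12` is tested in a functional assay on SW480 cells (Homo sapiens) for antiproliferative activity, read by MTT assay, with a stated time of 72 h (on this read-out higher numbers stand for weaker inhibition and lower numbers for stronger inhibition), where compound 1 gives 2500 nM. Compound 2 `O=c1cc(CSC(=S)N2CCOCC2)oc2cc(Cl)ccc12` shares that core and differs by morpholin-4-yl in place of piperidin-1-yl on a thiocarbonyl carbon. In this assay compound 2 reaches only the limit of > 25000 nM. The change made an at least 10-fold higher number from compound 1 to compound 2 (1.00 log units; beyond the scatter), a step that rests on (the limit of > 25000 nM in this assay, at which 2 of the 3 values shown sit). Compound 3 `CCOC(=O)c1cc(=O)c2cc(CSC(=S)N3CCCCC3)ccc2o1` has a different core; the difference between the two cores is not broken down here. In this assay compound 3 also reaches only the limit of > 25000 nM. Compound 4 `CCOC(=O)c1cc(=O)c2cc(CSC(=S)N3CCOCC3)ccc2o1` is not yet measured and differs from compound 3 by morpholin-4-yl in place of piperidin-1-yl on a thiocarbonyl carbon, the same change as before. Compound 3 already sits at the limit (the limit of > 25000 nM in this assay, at which 2 of the 3 values shown sit). The earlier step of an at least 10-fold higher number from compound 1 to compound 2 (1.00 log units; beyond the scatter) went the weakening way. On that ground the step that the limit leaves unreadable from compound 3 to compound 4 is expected, and compound 4 is estimated at 60000 nM, most likely reported only as a limit.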

Compound 4, half-maximal inhibitory concentration: > 25000 nM
Compound 4: a limit, no number; the forecaster's own chance of this, stated with the estimate: 90%; the middle value is on the limit's open side.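

Going by these compounds alone, compound 3 and compound 4 both give only a limit, so no step between them can be read: the limit of > 25000 nM in this assay, at which 3 of the 4 values shown sit. On these data alone, whether morpholin-4-yl in place of piperidin-1-yl changes activity on the core of compound 3 stays open.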